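Dimethylamino for acetoxy at the assay limit

The source may hold more compounds than are shown below. What is called first, only, known or untested is meant among the compounds shown, and "the series" means these compounds.

Measured in a functional assay on P388 cells (Mus musculus) for inhibition; a higher number here means a weaker inhibitor, a lower number a stronger inhibitor:
- compound 1 `COCCOc1cc(/C=C\c2ccc3ccccc3c2)ccc1OC` gives 2990 nM
- compound 2 `CC(=O)Oc1ccc(/C=C/c2ccc3ccccc3c2)cc1` gives > 5000 nM (a limit, not a number)

Compound 2 has only a limit in this assay and no number of its own. Compound 3 `CN(C)c1ccc(/C=C/c2ccc3ccccc3c2)cc1` differs from it by dimethylamino in place of acetoxy on an aromatic carbon in words, dimethylamino in place of acetoxy on an aromatic carbon, para to a large group. Among the compounds with values here, no measured step bears on this change. The expected step of a number no higher from compound 2 to compound 3 (the limit leaves the size open) is estimated to stay within the scatter, in neither direction. The expected value for compound 3 is 5000 nM within an estimated range of 2000 nM to 12000 nM and it may again return only a limit.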

Compound 3, half-maximal inhibitory concentration: 3660 nM
Estimate against measurement, compound 3: 1.4-fold (0.14 log units) above, within the range that was stated.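

In this assay, dimethylamino in place of acetoxy on an aromatic carbon, para to a large group, gives an at least 1.3-fold lower number from compound 2 to compound 3 (0.13 log units; that floor lies within the scatter) on the shared core. Compound 3 gives 3660 nM as a measured number. Compound 2 gives > 5000 nM as a limit and not a number, so the step reads only as a floor, because of this limit: the limit of > 5000 nM in this assay, at which 1 of the 3 values shown sits.

On these data alone, the size of the step beyond that floor stays open. Also open, as far as these compounds go, is how an unsubstituted amine, a hydroxyl or a carboxylic acid would read on this aromatic carbon.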